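A few compounds are considered here, and "the series" means these few. Any claim that something is new, unique, unknown or untested is made for them only; others in the source may bear on it.

Within the data shown here, compound 1 `O=c1nc2oc(C3CC3)c(C#CC3CC3)c2cn1Cc1cn(-c2ccccc2F)nn1` stands at 49100 nM in a functional assay on SW-620 cells (Homo sapiens) for antiproliferative activity, read by MTT assay, with a stated time of 72 h (a higher number here means a weaker inhibitor, a lower number a stronger inhibitor), the only actual number so far. Compound 2 `O=c1nc2oc(CCCCl)cc2cn1Cc1cn(-c2ccc(F)cc2)nn1` gives only a limit in this assay, > 100000 nM. Among the measured compounds shown here, that second value sits at the limit of > 100000 nM in this assay, at which 1 of the 2 values shown sits, so no measured step can be drawn from it. Compound 3 `O=c1nc2oc(C3CC3)c(C#CC3CC3)c2cn1Cc1cn(-c2ccc(Cl)cc2)nn1` differs from compound 1 by 4-chlorophenyl in place of 2-fluorophenyl on an aromatic nitrogen. For the measured compounds named here, no measured pair covers this exchange, since compound 2 differs from compound 1 in more than one place. The expected step is a 1.2-fold lower number from compound 1 to compound 3 (0.09 log units; within the scatter), no larger than the usual scatter. Compound 3 is estimated at 40000 nM, between 15000 nM and 100000 nM.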

Compound 3, half-maximal inhibitory concentration: 36900 nM
Estimate against measurement, compound 3: 1.1-fold (0.04 log units) above, within the range that was stated.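

In this assay, among these compounds, 4-chlorophenyl in place of 2-fluorophenyl on an aromatic nitrogen gives a 1.3-fold lower number from compound 1 to compound 3 (0.12 log units; within the scatter), the first measured step. Compound 1 and compound 3 therefore cannot be told apart at this position, so this exchange of one halogen-bearing phenyl for the other does not separate them. Nothing shown gives a cause for this result.

On these data alone, whether a phenyl bearing an amine or a carboxylic acid on this nitrogen would separate from compound 1 stays open. The same holds for a longer alkyl chain in place of the phenyl.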